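Methyl for Methoxy on Two Related Cores

This account rests on a few compounds, and the source may have more. Where it says the series, first, only, none or still open, it means among the compounds named here.

Compound 1 `COc1ccc2[nH]c(-c3ccc[nH]3)c(C3CC(=O)NC3=O)c2c1` and compound 3 `Cc1ccc2[nH]c(-c3ccc[nH]3)c(C3CC(=O)NC3=O)c2c1` share one core, while compound 2 `COc1ccc2[nH]c(-n3cccn3)cc2c1` and compound 4 `Cc1ccc2[nH]c(-n3cccn3)cc2c1` share another; the difference between the two cores is not broken down here. In a functional assay on B16-F10 cells (Mus musculus) for cytotoxicity, read by MTT assay, with a stated time of 72 h (on this read-out lower numbers stand for stronger inhibition and higher numbers for weaker inhibition), compound 1 gives 600 nM, and compound 3 gives 500 nM. The change methyl in place of methoxy on an aromatic carbon therefore made a 1.2-fold lower number from compound 1 to compound 3 (0.08 log units; within the scatter). For compound 2 the result in this assay is only a limit, > 100000 nM. Compound 4 carries the same change, (methyl in place of methoxy on an aromatic carbon), on the second core. Compound 4 is expected to give about 150000 nM, which would be an estimated step that the limit leaves unreadable from compound 2 to compound 4. That expectation rests on compound 2 sitting at the limit of > 100000 nM in this assay, at which 1 of the 3 values shown sits. It also rests on the step of a 1.2-fold lower number from compound 1 to compound 3 (0.08 log units; within the scatter), which left the number essentially where it had been.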

Compound 4, half-maximal inhibitory concentration: > 100000 nM
Compound 4: no number, only a limit; the forecaster's own chance of this, stated with the estimate: 85%; the middle value is on the limit's open side.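

In this assay compound 2 and compound 4 both give only a limit, not a number, so the step between them cannot be read. Going by these compounds, whether methyl in place of methoxy changes anything on the core of compound 2 stays open.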